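Removing the pyrrolidine from the amide of compound 1

The source may hold more compounds than are shown below. What is called first, only, known or untested is meant among the compounds shown, and "the series" means these compounds.

Measured compounds:
compound 1, `O=C(N[C@@H]1CCNC1)c1cc(-c2ccc(NS(=O)(=O)c3cccc(Cl)c3Cl)cc2)nc2[nH]ncc12`, < 1 nM
compound 2, `CN1CCC(NC(=O)c2cc(-c3ccc(NS(=O)(=O)c4cccc(Cl)c4Cl)cc3)nc3[nH]ncc23)C1`, 21 nM

In an assay for inhibition of serine/threonine-protein kinase Sgk1 (Homo sapiens), with stated times of 30 min and 60 min, in the presence of a further agent that is not named here (on this read-out higher numbers stand for weaker inhibition and lower numbers for stronger inhibition), compound 1 gives < 1 nM, and this is a limit of the assay rather than a number. That is where compound 1 stands: at the limit (the limit of < 1 nM in this assay, at which 1 of the 2 values shown sits), so its true value is not known more closely. Compound 2 gives 21 nM in this assay. Among the compounds with values here, the one measured step is an at least 21-fold higher number from compound 1 to compound 2 (1.32 log units; beyond the scatter), a change that keeps the ring but adds a methyl to its nitrogen.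

Compound 3 is `NC(=O)c1cc(-c2ccc(NS(=O)(=O)c3cccc(Cl)c3Cl)cc2)nc2[nH]ncc12`. It differs from compound 1 in that (hydrogen in place of pyrrolidin-3-yl on an amide-type nitrogen). The step from compound 1 to compound 2 is the only one that bears on this, and it was large, although its true size is hidden by the limit of compound 1. Taking the whole ring away is a larger change than adding a methyl to it, so a step at least as large is expected here, toward a higher number. Compound 3 is therefore expected to give 150 nM in this assay, within 15 nM to 1500 nM, which means an estimated at least 150-fold higher number from compound 1 to compound 3 (2.17 log units; beyond the scatter).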

Compound 3, half-maximal inhibitory concentration: 236 nM
The estimate for compound 3 lay 1.6-fold (0.20 log units) below the measured number, within the range that was stated.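

In this assay, hydrogen on the amide-type nitrogen proves a far poorer partner for the shared core than pyrrolidin-3-yl, with an at least 230-fold higher number from compound 1 to compound 3 (2.37 log units; beyond the scatter). The methylated ring also retains a clear advantage over hydrogen, with an 11-fold higher number from compound 2 to compound 3 (1.05 log units; beyond the scatter), so the gain from a ring at this position does not depend on its nitrogen being free of a methyl, even though the methyl itself carries a cost. The value of compound 1 is a limit and not a number, so the first of these steps gives only a minimum size and cannot be compared exactly with the second: the limit of < 1 nM in this assay, at which 1 of the 3 values shown sits.

The compounds shown leave open whether the gain comes from the ring itself or from the presence of an amine nitrogen on this substituent, a question that a cyclopentyl group, with no nitrogen in its ring, or an open 2-aminoethyl chain on the same amide-type nitrogen would help to answer. They also leave open how a larger ring, such as piperidin-4-yl, or the opposite stereocentre of the pyrrolidin-3-yl group would compare with compound 1.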